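Bromo for chloro on a hydroxymethyl-bearing core

The compounds below may be only part of what the source reports. "The series", "measured", "known", "first", "only" and "open" are said of these compounds alone.

Of the compounds shown here, three sharing one core have been measured in a functional assay on the whole organism (strain Wistar albino) for inhibition, with Rattus norvegicus as the target, read by paw edema, with a stated time of 1 h, at a dose of 100 mg/kg by the oral route; on this read-out lower numbers stand for less inhibition and higher numbers for more inhibition at the one dose given (going by the name of the read-out). Compound 1 `Cc1ccc2c(Cc3nn4cc(-c5ccc(Cl)cc5)nc4s3)coc2c1` gives 13.4% in this assay. Compound 2 `Cc1ccc2c(Cc3nn4cc(-c5ccc(Br)cc5)nc4s3)coc2c1` differs from compound 1 by bromo in place of chloro on an aromatic carbon, and compound 2 gives 10.3% in this assay; the step is a number 3.1 percentage points lower from compound 1 to compound 2 (within the scatter). Compound 3 `Cc1ccc2c(Cc3nn4c(CO)c(-c5ccc(Cl)cc5)nc4s3)coc2c1` differs from compound 1 by hydroxymethyl in place of hydrogen on an aromatic carbon, and compound 3 gives 14.5% in this assay; this step is a number 1.1 percentage points higher from compound 1 to compound 3 (within the scatter). All three numbers sit close together.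

Compound 4 `Cc1ccc2c(Cc3nn4c(CO)c(-c5ccc(Br)cc5)nc4s3)coc2c1` has not yet been measured. It differs from compound 3 by bromo in place of chloro on an aromatic carbon, the same change that separates compound 1 from compound 2, made once more on the core that carries the hydroxymethyl group. That earlier change, from compound 1 to compound 2, moved the number only slightly. The step from compound 3 to compound 4 in this assay is therefore expected to be about as small, a number 3 percentage points lower from compound 3 to compound 4 (within the scatter), because compound 3 gives 14.5% and the earlier step was a number 3.1 percentage points lower from compound 1 to compound 2 (within the scatter). Compound 4 is estimated to give 11.5%, with a range from 4% to 20%.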

Compound 4, a percentage reported as inhibition, in the whole organism at one dose (the size of the read-out at that dose, not a potency): 7.2%
Compound 4: middle estimate off by 4.3 percentage points, on the high side; the range from low to high includes it.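

On the core carrying the hydroxymethyl group, bromo in place of chloro gives a number 7.3 percentage points lower from compound 3 to compound 4 (within the scatter), and in this assay this step cannot be told apart from the same change on the core without that group: the same change on two cores in this assay, a number 3.1 percentage points lower (within the scatter) from compound 1 to compound 2 and a number 7.3 percentage points lower (within the scatter) from compound 3 to compound 4, 4.2 percentage points apart, within the scatter of two such steps. Hydroxymethyl in place of hydrogen, with bromo present, gives a number 3.1 percentage points lower from compound 2 to compound 4 (within the scatter), and this step likewise cannot be told apart from its counterpart with chloro present: the same change on two cores in this assay, a number 1.1 percentage points higher (within the scatter) from compound 1 to compound 3 and a number 3.1 percentage points lower (within the scatter) from compound 2 to compound 4, 4.2 percentage points apart, within the scatter of two such steps. The two changes therefore carry from one core to the other without a detectable difference, but every step here lies within the scatter, so this does not show that either change has a real effect, or that a real dependence on the core is absent.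

On these data alone, what remains open is whether another group on the same aromatic carbon, such as an amine or a carboxylic acid, would move the number beyond the scatter. As far as these compounds go, it is also open whether a longer chain in place of the hydroxymethyl group would do so.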